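The source may report more compounds than this note shows. Statements on the series, on what has been measured and on what is new or still open speak of the compounds shown alone.

Measured so far in a functional assay, read by fluorescence and spectrophotometry, with a stated time of 1 h; on this read-out lower numbers stand for an effect already at smaller amounts and higher numbers for an effect only at larger amounts of compound

- compound 1 `CCCCCS(=O)(=O)/C=C/c1ccc(O)c(O)c1` gives 8100 nM
- compound 2 `O=S(=O)(/C=C/c1ccc(O)c(O)c1)CCC1CCCC1` gives 6800 nM
- compound 3 `O=S(=O)(/C=C/c1ccc(O)c(O)c1)CCCCCCCCCO` gives 7500 nM

These numbers sit so close that nothing separates them. Compound 3 lies within the usual scatter of both compound 1 and compound 2, so it stands in a flat group of values.

Compound 4 `C=CCCCCCS(=O)(=O)/C=C/c1ccc(O)c(O)c1` has not been measured yet. Its difference from compound 3 is vinyl in place of 4-hydroxybutyl on a saturated chain carbon, five bonds along the chain from a sulfonyl sulfur.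

Among the measured compounds shown here, two measured steps bear on this change. The closer one is a 1.1-fold lower number from compound 1 to compound 3 (0.03 log units; within the scatter), with 4-hydroxybutyl in place of hydrogen at that same place. The other is a 1.2-fold lower number from compound 1 to compound 2 (0.08 log units; within the scatter), with cyclopentyl in place of propyl on a saturated chain carbon, two bonds along the chain from a sulfonyl sulfur. Both stay within the scatter, although neither involves a vinyl group.

On that basis, no change beyond the scatter is expected in this assay for this swap. The expected size is a 1.1-fold lower number from compound 3 to compound 4 (0.03 log units; within the scatter) and no more than that. The estimate for compound 4 is 7000 nM as a middle value, with an expected range from 3500 nM up to 14000 nM for repeated measurements.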

Compound 4, half-maximal effective concentration: 7100 nM
The estimate for compound 4 lay 1.0-fold (0.01 log units) below the measured number, and the stated range covers the measured number.
By their numbers in this assay, from the lowest: compounds 2, 4, 3 and 1 (each within the scatter of the next).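

In this assay, among the compounds shown here, the earlier compounds showed only that 4-hydroxybutyl could stand on a saturated chain carbon, five bonds along the chain from a sulfonyl sulfur, without moving the number beyond the scatter. The new result adds a different kind of group at that place, one with a double bond and with 0 hydrogen-bond donors, and the swap gives a 1.1-fold lower number from compound 3 to compound 4 (0.02 log units; within the scatter) as vinyl replaces 4-hydroxybutyl, while vinyl in place of hydrogen gives a 1.1-fold lower number from compound 1 to compound 4 (0.06 log units; within the scatter) and pent-4-en-1-yl in place of cyclopentyl gives a 1.0-fold higher number from compound 2 to compound 4 (0.02 log units; within the scatter) on this read-out. All four compounds therefore form one flat group with none going against it, and nothing measured here says why the values stay together.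

The compounds shown leave open whether any group at this place can move the number beyond the scatter, for example an amine, a carboxylic acid or a much longer chain. They also leave open how much of the effect depends on the shared core, since every compound here keeps it unchanged.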